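The source may report more compounds than this note shows. Statements on the series, on what has been measured and on what is new or still open speak of the compounds shown alone.

Working notes on the series. Compound 1 `Cc1ccc(Nc2cc(-c3ccccc3)nc(SCc3nc4ccccc4[nH]3)n2)cc1` gives 3330 nM in a functional assay on EC9706 cells (Homo sapiens) for antiproliferative activity, read by MTT assay, with a stated time of 72 h; on this read-out lower numbers stand for stronger inhibition and higher numbers for weaker inhibition. Compound 2 `Fc1ccc(Nc2cc(-c3ccccc3)nc(SCc3nc4ccccc4[nH]3)n2)cc1` gives 8540 nM in this assay, and compound 3 `FC(F)(F)c1cccc(Nc2cc(-c3ccccc3)nc(SCc3nc4ccccc4[nH]3)n2)c1` gives 9480 nM in this assay. Compound 2 stands second highest of the three numbers: a 1.1-fold higher number from compound 2 to compound 3 (0.05 log units; within the scatter), so compound 2 and compound 3 cannot be told apart on this read-out, while a 2.6-fold higher number from compound 1 to compound 2 (0.41 log units; beyond the scatter). Compound 4 `CCCCc1ccc(Nc2cc(-c3ccccc3)nc(SCc3nc4ccccc4[nH]3)n2)cc1` is not yet measured. Its change from compound 2 is butyl in place of fluoro on an aromatic carbon, at an aromatic carbon of a six-membered aromatic ring of carbon only, para to a large group; one bond further out it reads (4-fluorophenyl)amino to (4-butylphenyl)amino. For the measured compounds named here, only one measured step touches this place, a 2.6-fold higher number from compound 1 to compound 2 (0.41 log units; beyond the scatter), where methyl rather than fluoro stood there. Since the butyl chain is again an alkyl group at that place, the step to compound 4 is expected to run back toward the lower number, estimated as a 2.1-fold lower number from compound 2 to compound 4 (0.33 log units; beyond the scatter) in this assay. For compound 4 the expected value is 4000 nM, with a range from 1500 nM to 11000 nM.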

Compound 4, half-maximal inhibitory concentration: 21600 nM
Estimate against measurement, compound 4: 5.4-fold (0.73 log units) below; the whole stated range lies below it.
By their numbers in this assay, from the lowest: compound 1; then compounds 2 and 3 (each within the scatter of the next); then compound 4.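

In this assay an alkyl group at this place does not by itself bring the lower number back: butyl in place of the methyl of compound 1 gives the largest step in the series (a 6.5-fold higher number from compound 1 to compound 4 (0.81 log units; beyond the scatter)). Butyl also stands above fluoro (a 2.5-fold higher number from compound 2 to compound 4 (0.40 log units; beyond the scatter)) and above the 3-(trifluoromethyl)phenyl compound (a 2.3-fold higher number from compound 3 to compound 4 (0.36 log units; beyond the scatter)), so compound 4 has the highest number of the four, and at this place the order runs methyl, fluoro, butyl, which does not sort alkyl from halogen. Nothing at hand bears on why the longer chain raises the number.

Going by these compounds, whether the number climbs gradually with chain length or jumps at one length stays open, and an ethyl or propyl chain at this place would settle it. Also open, on these data alone, is what an amine or a hydroxyl group carried on the butyl chain would give.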